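The compounds below may be only part of what the source reports. "The series", "measured", "known", "first", "only" and "open" are said of these compounds alone.

Series notes. Three amidine analogues have so far been run in a functional assay on PC-3 cells (Homo sapiens) for cytotoxicity, read by MTT assay, with a stated time of 72 h; a higher number here means a weaker inhibitor, a lower number a stronger inhibitor. Compound 1, `COc1ccc(Cn2cc3cc(C(=N)Nc4cccc(C(F)(F)F)c4)ncc3n2)cc1`, gives 12800 nM in this assay. Compound 2, `CN1CCN(c2ccc(NC(=N)c3cc4cn(C)nc4cn3)cc2)CC1`, gives 24800 nM in this assay. Compound 3, `N=C(Nc1cccc(C(F)(F)F)c1)c1cc2c(-c3ccccc3)n[nH]c2cn1`, gives 19900 nM in this assay. Among these three numbers compound 3 holds the second highest; its nearest neighbour is compound 2, whose number sits within the scatter of it, and the furthest, compound 1, also lies within the scatter. For the measured compounds named here, the three values thus cannot be ranked against one another, and no two measured compounds differ in only one place, so no step between measured compounds is available for guidance.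

Compound 4, `N=C(Nc1ccccc1)c1cc2c(-c3ccccc3)n[nH]c2cn1`, is not yet measured in this assay. It differs from compound 3 in a single place: hydrogen in place of trifluoromethyl on an aromatic carbon. Going by the values given here, no measured pair in the set isolates this change, so what is expected rests on the change alone and on the narrow spread of compounds 1 to 3. The step from compound 3 to compound 4 is expected to be a 1.3-fold higher number from compound 3 to compound 4 (0.10 log units; within the scatter), meaning none beyond the scatter, with at most a slight lean toward a higher number. Compound 4 is expected to give about 25000 nM in this assay, within a range of 8000 nM to 80000 nM.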

Compound 4, half-maximal inhibitory concentration: 23000 nM
The estimate for compound 4 lay 1.1-fold (0.04 log units) above the measured number; low and high end bracket the measured number.
By their numbers in this assay, from the lowest: compounds 1, 3, 4 and 2 (each within the scatter of the next).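

Hydrogen in place of trifluoromethyl on an aromatic carbon now gives the series its first single-place step, which in this assay reads as a 1.2-fold higher number from compound 3 to compound 4 (0.06 log units; within the scatter) and so stays within the scatter. For this pair, on the shared core, the four heavy atoms of trifluoromethyl can therefore leave this position without a difference that can be told from the scatter, and the group is not required here for the number seen with compound 3. No measurement in hand bears on why this step is so small.

Still open, on these data alone, is whether any substituent at this aromatic carbon can move the number beyond the scatter, for example an amine or a carboxylic acid in place of the hydrogen of compound 4. Also open, as far as these compounds go, is what the phenyl group on the core of compound 4 contributes, which a single-place exchange for hydrogen or for a longer chain such as n-butyl would isolate.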